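The source may report more compounds than this note shows. Statements on the series, on what has been measured and on what is new or still open speak of the compounds shown alone.

The series shares one core and differs only in the group on a saturated chain carbon bound to an aromatic nitrogen. Compound 1 `COc1cc(Cc2nc3c(N)ncnc3n2CC2CCCCC2)cc(OC)c1OC` gives 39800 nM in a functional assay on MCF7 cells (Homo sapiens) for antiproliferative activity; on this read-out higher numbers stand for weaker inhibition and lower numbers for stronger inhibition. Compound 2 `CC/C=C/Cn1c(Cc2cc(OC)c(OC)c(OC)c2)nc2c(N)ncnc21` gives 46800 nM in this assay, and compound 3 `C#CCCCn1c(Cc2cc(OC)c(OC)c(OC)c2)nc2c(N)ncnc21` gives 24000 nM in this assay. Compound 3 stands at the low end of the three numbers shown, yet the steps of a 1.7-fold lower number from compound 1 to compound 3 (0.22 log units; within the scatter) and a 2.0-fold lower number from compound 2 to compound 3 (0.29 log units; within the scatter) both stay within the scatter, as does a 1.2-fold higher number from compound 1 to compound 2 (0.07 log units; within the scatter), so the three compounds cannot be separated. Compound 4 `CC/C=C\Cn1c(Cc2cc(OC)c(OC)c(OC)c2)nc2c(N)ncnc21` is not yet measured. The change from compound 3 is but-1-en-1-yl in place of but-3-yn-1-yl on a saturated chain carbon bound to an aromatic nitrogen. The step that bears on it most directly is a 2.0-fold lower number from compound 2 to compound 3 (0.29 log units; within the scatter), read in reverse, since compound 2 carries a group of the same name; a 1.2-fold higher number from compound 1 to compound 2 (0.07 log units; within the scatter) and a 1.7-fold lower number from compound 1 to compound 3 (0.22 log units; within the scatter) add nothing beyond the scatter either. A number close to that of compound 2 is therefore expected, with no step beyond the scatter in this assay. For compound 4 the estimate in this assay is 40000 nM, range 18000 nM to 90000 nM, an expected step of a 1.7-fold higher number from compound 3 to compound 4 (0.22 log units; within the scatter).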

Compound 4, half-maximal inhibitory concentration: 64600 nM
Compound 4: the middle estimate sits 1.6-fold (0.21 log units) below what was measured; the range from low to high includes it.
By their numbers in this assay, from the lowest: compounds 3, 1, 2 and 4 (each within the scatter of the next, the first and the last beyond it).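

In this assay the series now has its first step beyond the scatter on a saturated chain carbon bound to an aromatic nitrogen, with a 2.7-fold higher number from compound 3 to compound 4 (0.43 log units; beyond the scatter) for but-1-en-1-yl in place of but-3-yn-1-yl, and that step is modest. Compound 4 still cannot be separated from the cyclohexyl group of compound 1, as a 1.6-fold higher number from compound 1 to compound 4 (0.21 log units; within the scatter) shows. Nor can the two double-bond forms be separated, with a 1.4-fold higher number from compound 2 to compound 4 (0.14 log units; within the scatter) in a pair that isolates configuration at this position, so drawn geometry has no readable effect in this assay: the fact that compounds 2 and 4 differ only in the configuration as drawn.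

All four groups shown are plain hydrocarbons, and only compounds 3 and 4 are separated. From the compounds shown here alone, whether an amine, a carboxylic acid or a longer chain at this position would move the number well outside this narrow band remains open.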